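Cytotoxicity notes on side-chain variants of compound 1

This account rests on a few compounds, and the source may have more. Where it says the series, first, only, none or still open, it means among the compounds named here.

Measured compounds:
compound 1 `COc1c(N2CCN(CCC#N)C(C)C2)c(F)cc2c(=O)c(C(=O)O)cn(C3CC3)c12`: 500 ug/mL
compound 3 `CO/N=C(\C)CCN1CCN(c2c(F)cc3c(=O)c(C(=O)O)cn(C4CC4)c3c2OC)CC1C`: 157 ug/mL
compound 2 `CCOC(=O)CCN1CCN(c2c(F)cc3c(=O)c(C(=O)O)cn(C4CC4)c3c2OC)CC1C`: "not determined" (no result reported)

In an ADME assay on Vero cells (Chlorocebus sabaeus) for cytotoxicity, read by MTT assay, with a stated time of 72 h (a higher number here means that more compound is tolerated, a lower number that less compound is tolerated), compound 1 gives 500 ug/mL, the highest of the two numbers recorded. Among the measured compounds shown here, compound 3 gives 157 ug/mL, and the step of a 3.2-fold lower number from compound 1 to compound 3 (0.50 log units; beyond the scatter) is the only measured change at the same place on the chain. For compound 2 the result in this assay is "not determined" (no result reported).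

Compound 4 `CCO/N=C(\C)CCN1CCN(c2c(F)cc3c(=O)c(C(=O)O)cn(C4CC4)c3c2OC)CC1C` differs from compound 1 by a group of 6 heavy atoms (4 carbon, 1 nitrogen, 1 oxygen; no ring) in place of a group of 2 heavy atoms (1 carbon, 1 nitrogen; no ring), on a saturated chain carbon, two bonds along the chain from an amine nitrogen in a ring. The incoming group matches that of compound 3 in kind and is one carbon larger. For compound 4 a downward step of about that size is expected: a 3.8-fold lower number from compound 1 to compound 4 (0.59 log units; beyond the scatter). Compound 4 is therefore estimated at 130 ug/mL, with a range of 60 ug/mL to 300 ug/mL in this assay.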

Compound 4, half-maximal cytotoxic concentration: 88.4 ug/mL
Estimate against measurement, compound 4: 1.5-fold (0.17 log units) above; the measured number falls inside the stated range.
By their numbers in this assay, from the lowest: compounds 4 and 3 (each within the scatter of the next); then compound 1.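

Replacing the cyano group at this place brings a second drop, a 5.7-fold lower number from compound 1 to compound 4 (0.75 log units; beyond the scatter), so the fall seen with compound 3 is not confined to one incoming group. The added methyl on the saturated chain carbon bound to an oxygen on an unsaturated carbon gives a 1.8-fold lower number from compound 3 to compound 4 (0.25 log units; within the scatter), which leaves compounds 3 and 4 unseparated in this assay. No measurement at hand accounts for the drop from the cyano group.

From the compounds shown here alone, whether an amine or a carboxylic acid at this place would stay close to compound 1 remains open. Compound 2 has no number, so its steps cannot be read.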